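An Oxazole in Place of a Furan: What to Expect

The compounds below may be only part of what the source reports. "The series", "measured", "known", "first", "only" and "open" are said of these compounds alone.

Two compounds have so far been measured in an assay on isolated protein for inhibition of ubiquitin carboxyl-terminal hydrolase 7 (Homo sapiens), with stated times of 30 min and 2 h; on this read-out lower numbers stand for stronger inhibition and higher numbers for weaker inhibition:

compound 1, `Cn1nc2c(=O)n(CC3(O)CCN(Cc4ccc(-c5ccco5)cc4Cl)CC3)cnc2c1-c1ccc(CO)cc1`, gives 42.5 nM
compound 2, `Cn1nc2c(=O)n(CC3(O)CCN(Cc4ccc(-c5ccoc5)cc4Cl)CC3)cnc2c1-c1ccc(CN)cc1`, gives 177 nM

Compound 2 stands as the higher of the two numbers, so it is the weaker inhibitor of the pair; compound 1 gives the lower number, and the gap between them lies beyond the usual scatter of this assay. Compound 3, `Cn1nc2c(=O)n(CC3(O)CCN(Cc4ccc(-c5ncco5)cc4Cl)CC3)cnc2c1-c1ccc(CN)cc1`, has not yet been measured. It differs from compound 2 in one place: 1,3-oxazol-2-yl in place of furan-3-yl on an aromatic carbon. Going by the values given here, both groups are single five-membered aromatic rings of the same heavy-atom count, and nothing among the measured compounds shows how this particular exchange moves the numbers. A small step from compound 2 to compound 3 is therefore expected, with no clear direction, as a 1.1-fold higher number from compound 2 to compound 3 (0.05 log units; within the scatter). Compound 3 is estimated at 200 nM, within a range from 70 nM to 600 nM.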

Compound 3, half-maximal inhibitory concentration: 1120 nM
For compound 3 the middle estimate is 5.6-fold (0.75 log units) below the measured one; measured number above the stated range.
By their numbers in this assay, from the lowest: compound 1; then compound 2; then compound 3.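

In this assay, going by these compounds alone, the exchange of furan-3-yl for 1,3-oxazol-2-yl comes out as a 6.3-fold higher number from compound 2 to compound 3 (0.80 log units; beyond the scatter) and so makes this the first single-place comparison. It shows that this position, para to a large group and meta to a chloro group, does not treat two five-membered aromatic rings of the same heavy-atom count as interchangeable: the choice of ring alone moves the number beyond the scatter. The entering ring has a nitrogen as a second hetero atom, but nothing measured here says why the number rises.

Compound 1 and compound 2 differ in two places, so the gap between them cannot be assigned to either place. Also open, on these data alone, is how this position would respond to a 1,3-thiazol-2-yl ring, a phenyl ring or an amine.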